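The compounds below may be only part of what the source reports. "The series", "measured", "known", "first", "only" and "open" are said of these compounds alone.

Measured compounds:
- compound 1, `CCCNC(=O)c1cc(Oc2ccc(NC(=O)c3cc4cccnc4n(-c4ccc(F)cc4)c3=O)cc2)ccn1`, gives 62 nM in a functional assay on A549 cells (Homo sapiens) for antiproliferative activity, read by MTT assay, with a stated time of 72 h; on this read-out lower numbers stand for stronger inhibition and higher numbers for weaker inhibition.
- compound 2, `CCCNC(=O)c1cc(Oc2ccc(NC(=O)c3cc4cccnc4n(-c4ccc(OC)cc4)c3=O)cc2)ccn1`, gives 820 nM in this assay.

Among the two numbers shown, compound 2 stands highest, meaning the weaker inhibition; the only other compound, compound 1, has the lower number, and the two are separated by a step well beyond the scatter. Going by the values given here, that step, a 13-fold higher number from compound 1 to compound 2 (1.12 log units; beyond the scatter), is the single measured step that bears on what comes next, since it replaces the same group at the same place.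

Compound 3, `CCCNC(=O)c1cc(Oc2ccc(NC(=O)c3cc4cccnc4n(-c4ccc(F)c(Cl)c4)c3=O)cc2)ccn1`, has not yet been measured in this assay. It differs from compound 2 by 3-chloro-4-fluorophenyl in place of 4-methoxyphenyl on an aromatic nitrogen. The fluorine at the same position as in compound 1 returns, with a chlorine added. Removing the methoxy is the reverse of the move that raised the number so sharply from compound 1 to compound 2, so a large drop back toward compound 1 is expected. The chlorine is an added group without a measured precedent here, so the estimate is kept near compound 1 with a broad range. For compound 3 the expected step is a 10-fold lower number from compound 2 to compound 3 (1.01 log units; beyond the scatter). Compound 3 is therefore estimated at 80 nM, within a range from 25 nM to 300 nM.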

Compound 3, half-maximal inhibitory concentration: 590 nM
Compound 3: the middle estimate sits 7.4-fold (0.87 log units) below what was measured; the whole stated range lies below it.
By their numbers in this assay, from the lowest: compound 1; then compounds 3 and 2 (each within the scatter of the next).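

In this assay, exchanging 4-methoxyphenyl for 3-chloro-4-fluorophenyl on the aromatic nitrogen gives a 1.4-fold lower number from compound 2 to compound 3 (0.14 log units; within the scatter) and so does not separate these two compounds, even though the two groups share no substituent. Going by these compounds alone, the earlier pair showed only that this ring is sensitive to replacing fluoro with methoxy, whereas the new result shows that keeping the fluoro does not by itself preserve the low number of compound 1: adding one chloro to that ring gives a 9.5-fold higher number from compound 1 to compound 3 (0.98 log units; beyond the scatter) and is a clear loss of inhibition. The data offer no measurement that explains why the added chloro has this effect.

On these data alone, with a single chloro compound, it remains open whether the loss belongs to chloro in particular or would also follow from another small group on the same ring, such as methyl or a nitrile. As far as these compounds go, it is also open how this ring would respond to an amine or a carboxylic acid, and whether a plain phenyl with no substituent would fall nearer compound 1 or nearer compound 2 and compound 3.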